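Ring amine substitution and metabolic stability in the series

This account rests on a few compounds, and the source may have more. Where it says the series, first, only, none or still open, it means among the compounds named here.

Measured so far:
compound 1, `CC(C)n1cc(-c2ccnc3[nH]c(C4CCNCC4)cc23)ccc1=O`: < 3 uL/min
compound 2, `CNC(=O)CN1CCC(c2cc3c(-c4ccc(=O)n(C(C)C)c4)ccnc3[nH]2)CC1`: 8.6 uL/min

Compound 1 sits at the limit of an ADME assay on microsomes from liver (Homo sapiens) for metabolic stability (on this read-out higher numbers stand for fast clearance and lower numbers for slow clearance), (the limit of < 3 uL/min in this assay, at which 1 of the 2 values shown sits), so its number is not known. Compound 2 gives 8.6 uL/min in this assay and holds the only true number shown in the series. For the measured compounds named here, the one readable step is an at least 2.8-fold higher number from compound 1 to compound 2 (0.45 log units; beyond the scatter); it is bounded on one side only because compound 1 sits at the limit of < 3 uL/min in this assay, at which 1 of the 2 values shown sits.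

Compound 3, `CC(=O)N1CCC(c2cc3c(-c4ccc(=O)n(C(C)C)c4)ccnc3[nH]2)CC1`, differs from compound 2 by acetyl in place of (methylcarbamoyl)methyl on an amine nitrogen in a ring. The measured step concerns the entry of the group that leaves here, not the one that enters, so it bears on compound 3 only loosely: both compound 2 and compound 3 carry a group on the ring amine nitrogen, whereas compound 1 carries none. Going by the values given here, no measured step involves an acetyl. With only one capped and one uncapped compound to go on, no step beyond the scatter is expected. For compound 3 the expected step is a 1.1-fold lower number from compound 2 to compound 3 (0.03 log units; within the scatter). The estimate for compound 3 in this assay is 8 uL/min, between 3 uL/min and 20 uL/min.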

Compound 3, intrinsic clearance in a liver preparation (reported as CLH), per the amount of preparation that the assay uses: < 3 uL/min
Compound 3 gave a limit, no number; the forecaster's own chance of this, stated with the estimate: 20%; middle value at least 2.6-fold (0.42 log units) from the limit.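

In this assay compound 3 gives < 3 uL/min, which is a limit and not a number. Acetyl in place of (methylcarbamoyl)methyl on the ring amine nitrogen gives an at least 2.8-fold lower number from compound 2 to compound 3 (0.45 log units; beyond the scatter), so a group on this nitrogen does not by itself go with the higher number: the read-out here depends on which group is attached, and the comparison of compound 1 with compound 2 alone could not show this. The step is bounded on one side only, and the step between compound 1 and compound 3 cannot be read, because both compounds sit at the same limit: the limit of < 3 uL/min in this assay, at which 2 of the 3 values shown sit.

For the compounds shown here, how far compound 3 lies from compound 2, and whether compound 1 and compound 3 differ at all, stays open while compound 2 holds the only true number. Also open, on these data alone, is which feature of (methylcarbamoyl)methyl goes with the higher number, a question that a plain methyl, a longer chain ending in a carboxylic acid, or a chain ending in an amine on the same nitrogen could begin to separate.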